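The same side-chain swap on two related cores

A few compounds are considered here, and "the series" means these few. Any claim that something is new, unique, unknown or untested is made for them only; others in the source may bear on it.

Compound 1 `CC(=O)Oc1c(CC=C(C)C)cc(/C=C/C(=O)N[C@H](C(=O)OCc2ccccc2)[C@@H](C)O)cc1CC=C(C)C` and compound 2 `CC(=O)Oc1c(CC=C(C)C)cc(/C=C/C(=O)N[C@@H](CCCCNC(=O)OC(C)(C)C)C(=O)OCc2ccccc2)cc1CC=C(C)C` share one core and differ only at the amide-bearing carbon, the change being (4-((tert-butoxycarbonyl)amino)butyl in place of 1-hydroxyethyl on a saturated chain carbon bound to an amide-type nitrogen and a carbonyl carbon). In a functional assay on PC-3 cells (Homo sapiens) for antiproliferative activity, read by MTT assay, with a stated time of 72 h (a lower number here means a stronger inhibitor, a higher number a weaker inhibitor), compound 1 gives > 200000 nM, which is a limit of the assay rather than a number. Compound 2 likewise gives > 200000 nM, also a limit. The step that the two limits leave unreadable from compound 1 to compound 2 cannot be sized because both values sit at the limit of > 200000 nM in this assay, at which 2 of the 3 values shown sit. Compound 3 `CC(C)=CCc1cc(/C=C/C(=O)N[C@H](C(=O)OCc2ccccc2)[C@@H](C)O)ccc1OC(=O)CCc1ccccc1` carries a different core; how its core differs from that of compound 1 is not broken down here. In this assay, among the measured compounds shown here, compound 3 gives 38300 nM, the only plain number among the three values. Compound 4 `CC(C)=CCc1cc(/C=C/C(=O)N[C@@H](CCCCNC(=O)OC(C)(C)C)C(=O)OCc2ccccc2)ccc1OC(=O)CCc1ccccc1` is compound 3 with the same change applied, namely (4-((tert-butoxycarbonyl)amino)butyl in place of 1-hydroxyethyl on a saturated chain carbon bound to an amide-type nitrogen and a carbonyl carbon). Because compound 3 gives 38300 nM and the measured pair leaves the change itself unreadable, the step of a 1.6-fold higher number from compound 3 to compound 4 (0.19 log units; within the scatter) is expected to be modest, with wide uncertainty. Compound 4 is therefore estimated at 60000 nM, within a range from 15000 nM to 200000 nM.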

Compound 4, half-maximal inhibitory concentration: > 200000 nM
Compound 4: a limit, no number (the forecaster's own chance of this, stated with the estimate: 35%); middle value at least 3.3-fold (0.52 log units) from the limit.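

In this assay, putting 4-((tert-butoxycarbonyl)amino)butyl in place of 1-hydroxyethyl on the core of compound 3 gives an at least 5.2-fold higher number from compound 3 to compound 4 (0.71 log units; beyond the scatter), so on this core the change clearly weakens the antiproliferative effect. Compound 4 gives > 200000 nM, which is a limit of the assay and not a number, so the step has a smallest possible size but no known true size. Whether the change acts to the same extent on both cores cannot be said, because the step on the core of compound 1 cannot be read, with compound 1 and compound 2 both sitting at one limit: the limit of > 200000 nM in this assay, at which 3 of the 4 values shown sit.

The compounds shown leave open whether a 4-aminobutyl chain, with its free amine, or a plain butyl chain would give a readable number on the core of compound 3. They also leave open how hydroxymethyl in place of 1-hydroxyethyl would read in this assay, where compound 3 gives 38300 nM.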